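The source may hold more compounds than are shown below. What is called first, only, known or untested is meant among the compounds shown, and "the series" means these compounds.

Three measured compounds share one core, a ketone link and the same bicyclic sulfur-containing half; they differ on an aromatic nitrogen of the five-membered ring and at one further carbon of the core. Compound 1 `O=C(c1ccn2c1CSC2c1cccnc1)c1c[nH]c2cc(-c3ccc(F)cc3)ccc12` gives 6.4 mg/kg in a functional assay on the whole organism for inhibition, with Rattus norvegicus as the target (a higher number here means that more compound is needed for the effect, a lower number that less compound is needed), the highest of the three numbers. Going by the values given here, compound 2 `CN(C)C(=O)n1cc(C(=O)c2ccn3c2CSC3c2cccnc2)c2ccc(Cl)cc21` gives 1.4 mg/kg in this assay, and compound 3 `CN(C)C(=O)n1cc(C(=O)c2ccn3c2CSC3c2cccnc2)c2ccc(-c3ccccc3)cc21` gives 0.06 mg/kg; the only single-point step among them is a 23-fold lower number from compound 2 to compound 3 (1.37 log units; beyond the scatter). Compound 4 `NCCn1cc(C(=O)c2ccn3c2CSC3c2cccnc2)c2ccc(-c3ccc(F)cc3)cc21` arises from compound 1 by 2-aminoethyl in place of hydrogen on an aromatic nitrogen. Among the compounds with values here, no measured step alters this nitrogen alone: compound 1 carries hydrogen there, compounds 2 and 3 carry a substituent, and compound 3 also differs from compound 1 at the other carbon, so its low number cannot be assigned to either change. The pair of compound 1 and compound 3 shows that a substituted nitrogen goes together with a much lower number, which weighs toward a decrease, though the entering group here is a different one. Compound 4 is therefore expected to show a step down, a 4.3-fold lower number from compound 1 to compound 4 (0.63 log units; beyond the scatter), estimated at 1.5 mg/kg with a range from 0.2 mg/kg to 8 mg/kg.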

Compound 4, dose for half-maximal effect: 1.3 mg/kg
Compound 4: the middle estimate sits 1.2-fold (0.06 log units) above what was measured; the range from low to high includes it.
By their numbers in this assay, from the lowest: compound 3; then compounds 4 and 2 (each within the scatter of the next); then compound 1.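

In this assay, going by these compounds alone, a 4.9-fold lower number from compound 1 to compound 4 (0.69 log units; beyond the scatter) is the first step that alters the aromatic nitrogen alone, with 2-aminoethyl in place of hydrogen and the rest of compound 1 unchanged. The earlier compounds shown here could not separate a change at this nitrogen from a change at the other carbon of the core; this pair shows that substitution here, on its own, goes with a lower number beyond the scatter. Nothing at hand gives a reason for this step.

Still open, from the compounds shown here alone, is whether the amine matters or the chain alone suffices, which a 2-hydroxyethyl group, a plain ethyl group or a longer amine chain on this nitrogen would test. A carboxylic acid at the end of the chain, and the dimethylcarbamoyl group on the core of compound 4, also remain to be compared with 2-aminoethyl.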